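The source may report more compounds than this note shows. Statements on the series, on what has been measured and on what is new or still open speak of the compounds shown alone.

Measured compounds:
compound 1 `CCCCCCCCNc1nc(SCc2ccc(C(F)(F)F)cc2)nc2ccccc12` — 13400 nM
compound 2 `FC(F)(F)c1ccc(CSc2nc(N3CCCCC3)c3ccccc3n2)cc1` — > 50000 nM
compound 3 `FC(F)(F)c1ccc(CSc2nc(Nc3cccc(C(F)(F)F)c3)c3ccccc3n2)cc1` — 11700 nM

In a functional assay on HGC-27 cells (Homo sapiens) for cytotoxicity, read by MTT assay, with a stated time of 72 h (on this read-out higher numbers stand for weaker inhibition and lower numbers for stronger inhibition), compound 2 gives > 50000 nM, which is a limit of the assay, not a number. Compound 2 sits at the limit of > 50000 nM in this assay, at which 1 of the 3 values shown sits, the weakest read-out in the set. Compound 4 `COc1ccc(Nc2nc(SCc3ccc(C(F)(F)F)cc3)nc3ccccc23)cc1OC` differs from compound 2 by (3,4-dimethoxyphenyl)amino in place of piperidin-1-yl on an aromatic carbon. Among the measured compounds shown here, two measured steps bear on this change. Exchanging piperidin-1-yl for an arylamino group gave an at least 4.2-fold lower number from compound 2 to compound 3 (0.63 log units; beyond the scatter), and the reverse exchange of an amino group for piperidin-1-yl gave an at least 3.7-fold higher number from compound 1 to compound 2 (0.57 log units; beyond the scatter). Both point the same way: an amino substituent on that carbon lowers the number beyond the scatter. A comparable downward step is expected for compound 4, namely an at least 4.1-fold lower number from compound 2 to compound 4 (0.61 log units; beyond the scatter). Compound 4 is therefore estimated at 12000 nM, with a range from 5000 nM to 30000 nM.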

Compound 4, half-maximal inhibitory concentration: 17900 nM
Beside the measured number, compound 4's estimate is 1.5-fold (0.17 log units) below it; the measured number falls inside the stated range.
By their numbers in this assay, from the lowest: compounds 3, 1 and 4 (each within the scatter of the next). At a limit, above all of these: compound 2.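

In this assay, (3,4-dimethoxyphenyl)amino in place of piperidin-1-yl gives an at least 2.7-fold lower number from compound 2 to compound 4 (0.44 log units; beyond the scatter) on this aromatic carbon, so a third amino group with a nitrogen hydrogen departs from the piperidine compound. Compound 2 remains a limit of the assay, not a number: the limit of > 50000 nM in this assay, at which 1 of the 4 values shown sits. The groups on that nitrogen are not told apart, since a 1.5-fold higher number from compound 3 to compound 4 (0.18 log units; within the scatter) and a 1.3-fold higher number from compound 1 to compound 4 (0.13 log units; within the scatter) both lie within the scatter.

Open, as far as these compounds go, is whether the step follows the nitrogen hydrogen or the loss of the piperidine ring. An N-methylanilino or a dimethylamino group on this carbon would separate the two.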